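Swapping a Benzyl Group on a Triazole-Linked Chalcone

This account rests on a few compounds, and the source may have more. Where it says the series, first, only, none or still open, it means among the compounds named here.

Compound 1 `O=C(/C=C/c1ccc(OCc2cn(Cc3ccc(Br)cc3)nn2)cc1)c1ccc(Br)cc1` and compound 2 `O=C(/C=C/c1ccc(OCc2cn(Cc3ccccc3F)nn2)cc1)c1ccc(Br)cc1` share one core and differ by 2-fluorophenyl in place of 4-bromophenyl on a saturated chain carbon bound to an aromatic nitrogen. In a functional assay on HepG2 cells (Homo sapiens) for inhibition, read by MTT assay, with a stated time of 48 h, tested at 10 uM (a higher number here means more inhibition of growth at the concentration tested, a lower number less inhibition of growth), compound 1 gives 22%, and compound 2 gives 29%; the step of a number 7 percentage points higher from compound 1 to compound 2 (within the scatter). Compound 3 `COc1ccc(C(=O)/C=C/c2ccc(OCc3cn(Cc4ccc(Br)cc4)nn3)cc2)cc1` differs from compound 1 by methoxy in place of bromo on an aromatic carbon, and in this assay compound 3 gives 59%, the step being a number 37 percentage points higher from compound 1 to compound 3 (beyond the scatter). Compound 4 `COc1ccc(C(=O)/C=C/c2ccc(OCc3cn(Cc4ccccc4F)nn3)cc2)cc1` is not yet measured; it differs from compound 3 by 2-fluorophenyl in place of 4-bromophenyl on a saturated chain carbon bound to an aromatic nitrogen, the same change as from compound 1 to compound 2. Because that earlier step was a number 7 percentage points higher from compound 1 to compound 2 (within the scatter), a step of similar small size is expected here, a number 4 percentage points higher from compound 3 to compound 4 (within the scatter). The estimate for compound 4 in this assay is therefore 63%, with a range from 46% to 78%.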

Compound 4, percent growth inhibition at one concentration: 33%
Compound 4: middle estimate off by 30 percentage points, on the high side, outside the stated range (below it).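

The swap of 4-bromobenzyl to 2-fluorobenzyl comes with a number 26 percentage points lower from compound 3 to compound 4 (beyond the scatter), so in this assay its effect does not carry from one core to the other: the same change on two cores in this assay, a number 7 percentage points higher (within the scatter) from compound 1 to compound 2 and a number 26 percentage points lower (beyond the scatter) from compound 3 to compound 4, 33 percentage points apart, beyond the scatter of two such steps. Likewise, methoxy in place of bromo comes with a number 4 percentage points higher from compound 2 to compound 4 (within the scatter), so that change does not carry over either: the same change on two cores in this assay, a number 37 percentage points higher (beyond the scatter) from compound 1 to compound 3 and a number 4 percentage points higher (within the scatter) from compound 2 to compound 4, 33 percentage points apart, beyond the scatter of two such steps. These four compounds show that the size of each step depends on the group at the other end of the molecule, but they do not show why, nor how either change behaves on any other core.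

Going by these compounds, it remains open whether the result for compound 3 depends on the bromine, the fluorine or where each sits. A 4-fluorobenzyl or 2-bromobenzyl group on the core of compound 3 would help separate these possibilities.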